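The compounds below may be only part of what the source reports. "The series", "measured", "known", "first", "only" and "open" are said of these compounds alone.

Notes on the series. Compound 1 `COc1ccc(-c2nc3cn(C)nc3c(=O)[nH]2)cc1` has been measured in an assay on CHO cells for displacement of a labelled ligand from adenosine receptor A1 (Homo sapiens), read by scintillation counting, with a stated time of 120 min, tested at 1 uM (a higher number here means more inhibition at the concentration tested (going by the name of the read-out), a lower number less inhibition), where compound 1 gives 2%. Two other measured compounds serve for comparison: compound 2 `COc1ccc(-n2cc3nc(-c4cccs4)nc(N)c3n2)cc1`, which in this assay gives 28%, and compound 3 `COc1ccc(C(=O)Nc2nc(-c3ccc(OC)cc3)nc3cn(-c4ccccc4)nc23)cc1`, which in this assay gives 3%. Compound 1 stands lowest of the three numbers; the nearest is compound 3, whose reading lies within the scatter of compound 1, and the furthest is compound 2, whose reading lies beyond the scatter above compound 1. For the measured compounds named here, no step between measured compounds that differ in one place is available.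

The step of interest runs from compound 1 to compound 4 `Cn1cc2nc(-c3ccccc3)[nH]c(=O)c2n1`, not yet measured in this assay. The change is hydrogen in place of methoxy on an aromatic carbon. Going by the values given here, no measured pair shows what this change does, so the expectation rests on compound 1 alone, whose reading 2% sits near the bottom of the scale. A step no larger than the usual scatter is expected, in no clear direction. Compound 4 is therefore expected to give about 3% in this assay, within -5% to 14%, an expected step of a number 1 percentage points higher from compound 1 to compound 4 (within the scatter).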

Compound 4, a percentage reported as inhibition, at one concentration (the size of the read-out at that concentration, not a potency): 1%
Compound 4: middle estimate off by 2 percentage points, on the high side; measured number inside the range.
By their numbers in this assay, from the lowest: compounds 4, 1 and 3 (each within the scatter of the next); then compound 2.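

In this assay, hydrogen in place of methoxy on the aromatic carbon para to a large group gives a number 1 percentage points lower from compound 1 to compound 4 (within the scatter), the only one-place step shown in the series. On this core, then, the reading stays near the bottom of the scale with or without the methoxy, and this change brings no inhibition into view at the concentration tested. With compound 1 already reading so low, any loss from this change could hardly show, so the step says little about whether the methoxy contributes at all. No measured evidence bears on the reason for this result.

From the compounds shown here alone, whether another group on this carbon, such as an amine, a carboxylic acid or a chlorine, would move the reading beyond the scatter stays open. Also open is what this same change does on a compound with a reading well clear of the bottom of the scale, since the one step shown starts from near the bottom.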